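A few compounds are considered here, and "the series" means these few. Any claim that something is new, unique, unknown or untested is made for them only; others in the source may bear on it.

Compound 1 `N#CC1=C(N)N(c2ccc(S(N)(=O)=O)cc2)C2=C(C(=O)CCC2)C1c1ccc(O)cc1` stands highest of the three compounds measured in a functional assay on Ehrlich cells (Mus musculus) for antiproliferative activity, read by trypan blue exclusion, with a stated time of 2 h, tested at 50 ug/mL (a higher number here means a stronger effect of the compound at the concentration tested, a lower number a weaker effect), where compound 1 gives 100%. Compound 2 `N#CC1=C(N)N(c2ccc(S(N)(=O)=O)cc2)C2=C(C(=O)CCC2)C1c1cccc([N+](=O)[O-])c1` gives 73%, and the change a number 27 percentage points lower from compound 1 to compound 2 (beyond the scatter) is modest. Compound 3 `N#CC1=C(N)N(c2ccc(S(N)(=O)=O)cc2)C2=C(C(=O)CCC2)C1c1c(O)ccc2ccccc12` gives 5%, and the change a number 95 percentage points lower from compound 1 to compound 3 (beyond the scatter) is large; the change a number 68 percentage points lower from compound 2 to compound 3 (beyond the scatter) is likewise large. The account now follows the step from compound 1 to compound 4 `COc1ccc(C2C(C#N)=C(N)N(c3ccc(S(N)(=O)=O)cc3)C3=C2C(=O)CCC3)c2ccccc12`, in which the difference is 4-methoxynaphthalen-1-yl in place of 4-hydroxyphenyl on a saturated ring carbon. Among the compounds with values here, the step that bears most directly on this change is the one from compound 1 to compound 3, since both replace the 4-hydroxyphenyl by a naphthalen-1-yl group, and it was a number 95 percentage points lower from compound 1 to compound 3 (beyond the scatter). The step from compound 1 to compound 2, a number 27 percentage points lower from compound 1 to compound 2 (beyond the scatter), shows that a smaller change at the same saturated ring carbon also lowered the number, though by less. A large fall in this assay is therefore expected, with the estimated step of a number 70 percentage points lower from compound 1 to compound 4 (beyond the scatter). For compound 4 the estimate in this assay is 30%, within a range from 5% to 70%.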

Compound 4, a percentage reported as activity, at one concentration (the size of the read-out at that concentration, not a potency): 30%
Compound 4: middle estimate and measured number agree at the digits printed; the range from low to high includes it.
By their numbers in this assay, from the lowest: compound 3; then compound 4; then compound 2; then compound 1.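

In this assay the second aromatic ring alone does not set the level, since 4-methoxynaphthalen-1-yl in place of 2-hydroxynaphthalen-1-yl on this saturated ring carbon gives a number 25 percentage points higher from compound 3 to compound 4 (beyond the scatter) and so the two naphthalen-1-yl groups are not equivalent here. Compound 4 still falls short of both single-ring compounds, with a number 70 percentage points lower from compound 1 to compound 4 (beyond the scatter) and a number 43 percentage points lower from compound 2 to compound 4 (beyond the scatter) as the steps that place 4-methoxynaphthalen-1-yl under 4-hydroxyphenyl and 3-nitrophenyl. Nothing available here accounts for these differences.

Compound 3 and compound 4 differ in both the oxygen substituent and its place on the naphthalene, so the compounds shown cannot separate these two changes. A 4-hydroxynaphthalen-1-yl or 4-methoxyphenyl group would divide them, while a 4-aminophenyl group would test whether an amine can stand in for the hydroxyl.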